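Ethyl for vinyl in a cell toxicity test

A few compounds are considered here, and "the series" means these few. Any claim that something is new, unique, unknown or untested is made for them only; others in the source may bear on it.

In an ADME assay on MT4 cells (Homo sapiens) for cytotoxicity, with a stated time of 5 days (on this read-out higher numbers stand for lower toxicity in this test and lower numbers for higher toxicity in this test), compound 1 `N#C[C@]1(CO)O[C@@H](c2ccc3c(N)ncnn23)[C@H](F)[C@@H]1O` gives > 114000 nM as its reading, which is a limit and not a number. Compound 2 `C=C[C@]1(CO)O[C@@H](c2ccc3c(N)ncnn23)[C@H](F)[C@@H]1O` likewise gives > 114000 nM in this assay and this too is only a limit. Between them lies a step that the two limits leave unreadable from compound 1 to compound 2 and so the one measured step offers no size to carry forward. For compound 1 and compound 2 the evidence is the limit of > 114000 nM in this assay, at which 2 of the 2 values shown sit, and nothing firmer.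

Compound 3 `CC[C@]1(CO)O[C@@H](c2ccc3c(N)ncnn23)[C@H](F)[C@@H]1O` has ethyl in place of vinyl on a saturated ring carbon, a change counted as ethyl in place of vinyl on a saturated ring carbon on an otherwise shared core. Among the measured compounds shown here, no measured step points to a rise or a fall in this assay for this swap, so no step beyond the usual scatter is expected. Compound 2 stands at > 114000 nM and that limit is the only anchor for the expectation. The estimated change is a number no higher from compound 2 to compound 3 (the limit leaves the size open) and it is expected to stay within the scatter. For compound 3 the expected value is 114000 nM within an estimated range of 50000 nM to 200000 nM and a reading given only as a limit is the likeliest outcome.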

Compound 3, half-maximal cytotoxic concentration: > 114000 nM
Compound 3 gave a limit, no number; the forecaster's own chance of this, stated with the estimate: 80%; the middle value sits exactly at the limit.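

Compound 1, compound 2 and compound 3 all remain limits rather than numbers in this assay, so no new step among them can be read: the limit of > 114000 nM in this assay, at which 3 of the 3 values shown sit.

The compounds shown leave open what actual number each of the three would give, and whether cyano, vinyl and ethyl on a saturated ring carbon differ at all in this read-out.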